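Hydroxy addition on the chlorophenyl arm of compound 3

A few compounds are considered here, and "the series" means these few. Any claim that something is new, unique, unknown or untested is made for them only; others in the source may bear on it.

Working notes on a small set of bis-benzylidene cyclohexanones tested in a functional assay on HT-1080 cells (Homo sapiens) for cytotoxicity, read by MTT assay, with a stated time of 72 h; a higher number here means a weaker inhibitor, a lower number a stronger inhibitor. Compound 1 `COc1cccc(/C=C2\CCC/C(=C\c3cccc(Br)c3)C2=O)c1OC` gives 12200 nM. Compound 2 `COc1cc(/C=C2\CCC/C(=C\c3cccc(OC)c3OC)C2=O)ccc1O` gives 5900 nM. Compound 3 `COc1ccc(/C=C2\CCC/C(=C\c3cccc(Cl)c3)C2=O)cc1OC` gives 4900 nM, which sits within the scatter of compound 2 and is a lower number than compound 1. Going by the values given here, the one single-point step in the set is a 2.1-fold lower number from compound 1 to compound 2 (0.32 log units; beyond the scatter).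

Compound 4 `COc1ccc(/C=C2\CCC/C(=C\c3ccc(O)c(Cl)c3)C2=O)cc1OC` differs from compound 3 by hydroxy in place of hydrogen on an aromatic carbon, so the 3-chlorophenyl arm becomes 3-chloro-4-hydroxyphenyl. Among the compounds with values here, the step from compound 1 to compound 2 is the only measured change that also introduces a hydroxy onto one aryl arm, but it swaps the halogen at the same time, so it bears on the present step only loosely; its size was modest. The expectation for compound 4 in this assay is therefore a small move toward a lower number, likely not beyond the scatter, as a 1.2-fold lower number from compound 3 to compound 4 (0.09 log units; within the scatter). Compound 4 is estimated at 4000 nM, with a range from 1800 nM to 9000 nM.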

Compound 4, half-maximal inhibitory concentration: 7600 nM
Beside the measured number, compound 4's estimate is 1.9-fold (0.28 log units) below it; low and high end bracket the measured number.
By their numbers in this assay, from the lowest: compounds 3, 2, 4 and 1 (each within the scatter of the next, the first and the last beyond it).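

In this assay, hydroxy in place of hydrogen on the aromatic carbon ortho to a chloro group and para to a large group gives a 1.6-fold higher number from compound 3 to compound 4 (0.19 log units; within the scatter) and so leaves no step beyond the scatter at this position. Going by these compounds alone, the earlier step, a 2.1-fold lower number from compound 1 to compound 2 (0.32 log units; beyond the scatter), replaces a whole aryl arm, whereas this one isolates the hydroxy as the only change, on the 3-chlorophenyl arm of an otherwise unchanged compound. No measurement here bears on the cause of this result.

The compounds shown leave open how an amine or a carboxylic acid would read on this same aromatic carbon. Also open, as far as these compounds go, is whether the hydroxy would read the same with the chloro group gone or with a different second arm on the shared core.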